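The compounds below may be only part of what the source reports. "The series", "measured", "known", "first", "only" and "open" are said of these compounds alone.

Measured compounds: compound 1 `CC(=O)/C(=N\Nc1ccccc1[N+](=O)[O-])N(C)c1cccc(Cl)c1` with 8600 nM in an assay on isolated protein for binding affinity to corticotropin-releasing factor receptor 1 (Homo sapiens); on this read-out higher numbers stand for weaker inhibition and lower numbers for stronger inhibition; compound 2 `CC(=O)/C(=N\Nc1ccccc1)Nc1cccc(Cl)c1` with 2720 nM; 2720 nM (2 entries) in this assay, given twice.

Within the data shown here, compound 1 stands alone on its one number; a further entry for it gives no single value. Compound 3 `CC(=O)/C(=N\Nc1ccccc1)N(C)c1cccc(Cl)c1` differs from compound 1 by hydrogen in place of nitro on an aromatic carbon. Among the measured compounds shown here, no step between measured compounds covers this change, so only a modest move is expected, at most a small gain that may not clear the scatter; the expected step is a 2.2-fold lower number from compound 1 to compound 3 (0.33 log units; beyond the scatter). Compound 3 is thus estimated at 4000 nM, within 1500 nM to 12000 nM.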

Compound 3, inhibition constant: > 10000 nM
Compound 3: only a limit was reported; the forecaster's own chance of this, stated with the estimate: 10%; at least 2.5-fold (0.39 log units) between middle value and limit.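

Replacing the nitro, ortho to a large group, with hydrogen brings no lower number in this assay: the change gives an at least 1.1-fold higher number from compound 1 to compound 3 (0.06 log units; that floor lies within the scatter). The nitro is thus not shown to be a burden at this position, though nothing shows that it helps either. For compound 3 the size of the step stays unknown because its reading is a limit and not a number: the limit of > 10000 nM in this assay, at which 1 of the 3 values shown sits.

From the compounds shown here alone, whether an amine or a methoxy group at this position would give a lower number than compound 1 stays open.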